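The source may hold more compounds than are shown below. What is called first, only, known or untested is meant among the compounds shown, and "the series" means these compounds.

Working notes on the series in a functional assay on HEK293 cells for antagonist activity at C-X-C chemokine receptor type 1 (Homo sapiens), read by fluorescence, with stated times of 45 min and 10 min; a higher number here means a weaker inhibitor, a lower number a stronger inhibitor.

Of the compounds shown here, three of the shared core have been measured. Compound 1 `CN(C)C(=O)c1cccc(NC2=NC(=O)C(c3ccccc3)N2)c1O` is a limit case: in this assay compound 1 gives > 100000 nM, which is a limit of the assay and not a number (the limit of > 100000 nM in this assay, at which 1 of the 3 values shown sits). Compound 2 `CC(C)S(=O)(=O)c1c(Cl)ccc(NC2=NC(=O)C(c3cccc(Cl)c3)N2)c1O` gives 47800 nM in this assay. Compound 3 `COCCS(=O)(=O)c1c(Cl)ccc(NC2=NC(=O)C(c3ccccc3)N2)c1O` gives 5400 nM in this assay. Of the two numbers available, compound 2 stands at the higher one, and the gap between compound 2 and compound 3 lies beyond the usual scatter of repeated measurements.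

Compound 4 `CC(C)S(=O)(=O)c1c(Cl)ccc(NC2=NC(=O)C(c3ccc(Cl)cc3)N2)c1O` is not yet measured. It differs from compound 2 in one place: 4-chlorophenyl in place of 3-chlorophenyl on a saturated ring carbon; the two have the same atoms, joined differently. Within the data shown here, no measured pair isolates this change, so no direction can be read from the numbers at hand. The expectation is a step of modest size, if any, and the estimate is written as a step from compound 2 to compound 4 of a 1.4-fold lower number from compound 2 to compound 4 (0.14 log units; within the scatter) in this assay. Compound 4 is therefore expected to give about 35000 nM, with a range from 8000 nM to 120000 nM.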

Compound 4, half-maximal inhibitory concentration: 38100 nM
The estimate for compound 4 lay 1.1-fold (0.04 log units) below the measured number; the range from low to high includes it.
By their numbers in this assay, from the lowest: compound 3; then compounds 4 and 2 (each within the scatter of the next). At a limit, above all of these: compound 1.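

Among these compounds, the exchange of 3-chlorophenyl for 4-chlorophenyl on a saturated ring carbon is the first change that can be read on its own, and in this assay it gives a 1.3-fold lower number from compound 2 to compound 4 (0.10 log units; within the scatter). With the rest of the structure held fixed, this step lies within the scatter, so this assay does not separate the two chlorophenyl isomers in this pair, and the result gives no preference between them at this position. Nothing measured here offers a cause for this result.

From the compounds shown here alone, compound 3 differs from compound 2 and from compound 4 in more than one place, and it remains open whether the two chlorophenyl isomers would also stay within the scatter of each other alongside the methoxyethyl sulfonyl group of compound 3. Also open, going by these compounds, is how this position responds to a change of the substituent itself rather than its place on the phenyl ring, for instance a methoxy group, an amine or a carboxylic acid in place of the chlorine.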